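Ethyl to methyl on the shared core

The source may report more compounds than this note shows. Statements on the series, on what has been measured and on what is new or still open speak of the compounds shown alone.

Of the compounds shown here, two have numbers so far in a functional assay (aorta) for inhibition, with Oryctolagus cuniculus as the target; on this read-out higher numbers stand for weaker inhibition and lower numbers for stronger inhibition. Compound 1 `COC(=O)C1=C(C)N=C(C)/C(=C(/O)OC)C1(C)c1cccc([N+](=O)[O-])c1` gives 2.3 ug/mL, and compound 2 `CCC1(c2ccccc2)C(C(=O)OC)=C(C)N=C(C)/C1=C(/O)OC` gives 3.6 ug/mL. These two values lie within the scatter of each other, so compound 2 stands level with compound 1 on the numbers available.

Compound 3 `COC(=O)C1=C(C)N=C(C)/C(=C(/O)OC)C1(C)c1ccccc1` differs from compound 2 in one place: hydrogen in place of methyl on a saturated chain carbon bound to a saturated ring carbon. This is hydrogen in place of methyl on a saturated chain carbon bound to a saturated ring carbon, so the ethyl of compound 2 becomes a methyl. Among the measured compounds shown here, no measured pair shows what this change does in this assay, so the expectation rests on the closeness of the two known values. The expected size of the change is a 1.2-fold lower number from compound 2 to compound 3 (0.08 log units; within the scatter), which is none beyond the scatter. For compound 3 the estimated value is 3 ug/mL, with an expected range from 1.2 ug/mL to 7.5 ug/mL.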

Compound 3, half-maximal inhibitory concentration: 1.2 ug/mL
The estimate for compound 3 lay 2.5-fold (0.40 log units) above the measured number; measured number inside the range.
By their numbers in this assay, from the lowest: compounds 3, 1 and 2 (each within the scatter of the next, the first and the last beyond it).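

Hydrogen in place of methyl on a saturated chain carbon bound to a saturated ring carbon gives a 3.0-fold lower number from compound 2 to compound 3 (0.48 log units; beyond the scatter) in this assay; this is the first step in the series to lie beyond the scatter, and it shows that the read-out responds to ethyl versus methyl at this position. Hydrogen in place of nitro on an aromatic carbon gives a 1.9-fold lower number from compound 1 to compound 3 (0.28 log units; within the scatter), so this single pair shows no separation between the nitro compound and its unsubstituted counterpart. Nothing available explains either result.

On these data alone, the effect of chain length rests on one pair, so it remains open whether a longer chain, such as propyl, would continue the direction seen from ethyl to methyl. Also open, as far as these compounds go, is how an amine or a carboxylic acid would read on the aromatic carbon that carries the nitro group.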